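Amide tail variation: from compound 2 to compound 4

The source may hold more compounds than are shown below. What is called first, only, known or untested is meant among the compounds shown, and "the series" means these compounds.

Measured compounds, with their values in an assay on isolated protein for inhibition of serine/threonine-protein kinase TBK1 (Homo sapiens); a higher number here means a weaker inhibitor, a lower number a stronger inhibitor:
Compound 1 `O=C(NCCCNc1nc(Nc2cccnc2)ncc1C1CC1)C1CCC1` gives 13 nM.
Compound 2 `COCCC(=O)NCCCNc1nc(Nc2cccc(F)c2)ncc1Br` gives 60 nM.
Compound 3 `CN(C)Cc1ccc(Nc2ncc(C3CC3)c(NCCCNC(=O)C3CCC3)n2)cc1` gives 6 nM.

Compound 2 stands at the highest number of the three; compound 1 sits lower and compound 3 lower still, both gaps beyond the scatter. Among the measured compounds shown here, the single one-place step measured, a 2.2-fold lower number from compound 1 to compound 3 (0.34 log units; beyond the scatter), concerns the group on a nitrogen on an aromatic ring and leaves the amide tail untouched.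

Compound 4 `O=C(CCc1ccccc1)NCCCNc1nc(Nc2cccc(F)c2)ncc1Br` differs from compound 2 by phenyl in place of methoxy on a saturated chain carbon, two bonds along the chain from a carbonyl carbon. For the measured compounds named here, no measured step bears on this change, so no direction can be read from the series; the step of a 1.2-fold lower number from compound 2 to compound 4 (0.08 log units; within the scatter) is expected to be small against a wide range. Compound 4 is estimated at 50 nM in this assay, between 15 nM and 160 nM.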

Compound 4, half-maximal inhibitory concentration: 560 nM
For compound 4 the middle estimate is 11-fold (1.05 log units) below the measured one, outside the stated range (above it).
By their numbers in this assay, from the lowest: compound 3; then compound 1; then compound 2; then compound 4.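

In this assay, among the compounds shown here, a 9.3-fold higher number from compound 2 to compound 4 (0.97 log units; beyond the scatter) is the first reading on the amide tail: phenyl in place of methoxy on a saturated chain carbon, two bonds along the chain from a carbonyl carbon, does not leave the number unchanged. For the compounds shown here, the earlier steps did not touch this position, so this is the first sign that the tail end affects the number. Nothing at hand bears on why the number rises.

With one pair, the loss of methoxy cannot be separated from the entry of phenyl. As far as these compounds go, whether a hydroxyl, an amine or a cyclohexyl group at this carbon would stay closer to compound 2 remains open.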